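Longer chain on a compound held at a limit

A few compounds are considered here, and "the series" means these few. Any claim that something is new, unique, unknown or untested is made for them only; others in the source may bear on it.

Measured in a functional assay on EC9706 cells (Homo sapiens) for antiproliferative activity, read by MTT assay, with a stated time of 48 h; a lower number here means a stronger inhibitor, a higher number a weaker inhibitor:
- compound 1 `CCCCCCCCCn1cc(COC[C@@H]2OC[C@H](N)[C@@H]2O)nn1`: 20100 nM
- compound 2 `CCCCCCCCCCCCCCn1cc(COC[C@@H]2OC[C@H](N)[C@@H]2O)nn1`: 7830 nM
- compound 3 `CCCCCCCCCn1cc(COC[C@@H]2OC[C@H](N)[C@H]2O)nn1`: > 128000 nM (a limit)

For compound 3, > 128000 nM is a limit of the assay and not a number.

Compound 4 `CCCCCCCCCCCCCCn1cc(COC[C@@H]2OC[C@H](N)[C@H]2O)nn1` differs from compound 3 by pentyl in place of hydrogen on a saturated chain carbon, nine bonds along the chain from an aromatic nitrogen. The same change gave a modest step of a 2.6-fold lower number from compound 1 to compound 2 (0.41 log units; beyond the scatter). Configuration also counts: the step of an at least 6.3-fold higher number from compound 1 to compound 3 (0.80 log units; beyond the scatter) goes with the fact that compounds 1 and 3 differ only in the configuration as drawn, and compound 4 keeps the configuration of compound 3. In this assay a modest fall is therefore expected, though the result could stay at the limit. The expected step is an at least 2.5-fold lower number from compound 3 to compound 4 (0.40 log units; beyond the scatter). For compound 4 the estimated value is 50000 nM, with an expected range from 15000 nM to 128000 nM.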

Compound 4, half-maximal inhibitory concentration: 6680 nM
The estimate for compound 4 lay 7.5-fold (0.87 log units) above the measured number; the measured number lies below the stated range.
By their numbers in this assay, from the lowest: compounds 4 and 2 (each within the scatter of the next); then compound 1. At a limit, above all of these: compound 3.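

In this assay, the added pentyl gives an at least 19-fold lower number from compound 3 to compound 4 (1.28 log units; beyond the scatter), so the same change on the two configurations of the core does not have the same size: the same change on two cores in this assay, a 2.6-fold lower number (0.41 log units; beyond the scatter) from compound 1 to compound 2 and an at least 19-fold lower number (1.28 log units; beyond the scatter) from compound 3 to compound 4, at least 7.4-fold (0.87 log units) apart, beyond the scatter of two such steps. Compound 3 gives > 128000 nM, which is a limit of the assay and not a number. With the longer chain in place, the change of configuration gives only a 1.2-fold lower number from compound 2 to compound 4 (0.07 log units; within the scatter), so the gap seen with the shorter chain does not persist: the fact that compounds 2 and 4 differ only in the configuration as drawn.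

From the compounds shown here alone, whether a still longer chain, or a chain ending in an amine or a carboxylic acid, would keep the two configurations level remains open.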